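Hydrogen for one methoxy on compound 1

A few compounds are considered here, and "the series" means these few. Any claim that something is new, unique, unknown or untested is made for them only; others in the source may bear on it.

In a functional assay on HeLa cells (Homo sapiens) for antiproliferative activity, read by sulforhodamine B assay, with a stated time of 48 h (on this read-out lower numbers stand for stronger inhibition and higher numbers for weaker inhibition), compound 1 `COc1cc(C(=O)/C=C\Nc2ccc(-c3nc4cc(OC)c(OC)c(OC)c4s3)cc2C)cc([N+](=O)[O-])c1OC` gives 13100 nM and lies within the scatter of both compound 2 `COc1cc(OC)c2sc(-c3ccc(N/C=C\C(=O)c4ccc(OC)c(O)c4)cc3)nc2c1` at 12100 nM and compound 3 `COc1ccc2nc(-c3ccc(N/C=C\C(=O)c4cc(OC)c(OC)c(OC)c4)c(C)c3)sc2c1` at 16100 nM in the same read-out. The step to compound 4 `COc1ccc(C(=O)/C=C\Nc2ccc(-c3nc4cc(OC)c(OC)c(OC)c4s3)cc2C)cc1[N+](=O)[O-]` is hydrogen in place of methoxy on an aromatic carbon at one place: hydrogen in place of methoxy on an aromatic carbon, ortho to a methoxy group and meta to a nitro group. For the measured compounds named here, no measured pair isolates a single change. Compound 2 and compound 3 differ from compound 1 in several places, yet stay within the scatter of its 13100 nM value, so little movement is expected here. The estimated step is a 1.1-fold higher number from compound 1 to compound 4 (0.03 log units; within the scatter) and is expected to stay within the scatter, with no firm direction. Compound 4 is estimated at 14000 nM with an expected range of 6000 nM to 32000 nM in this assay for now.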

Compound 4, half-maximal inhibitory concentration: 13400 nM
Beside the measured number, compound 4's estimate is 1.0-fold (0.02 log units) above it, within the range that was stated.
By their numbers in this assay, from the lowest: compounds 2, 1, 4 and 3 (each within the scatter of the next).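

In this assay, for the compounds shown here, hydrogen in place of methoxy on an aromatic carbon gives a 1.0-fold higher number from compound 1 to compound 4 (0.01 log units; within the scatter) and is the first step that changes a single place. At this place, ortho to a methoxy group and meta to a nitro group, loss of the methoxy leaves the number within the scatter. No evidence on hand gives a reason for this. Open, as far as these compounds go, is whether an amine or a carboxylic acid at this place would move the number. Also open, from the compounds shown here alone, is whether removing the neighbouring nitro group would do so.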